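Adding a (3-methylphenyl)carbonyl group to compound 1

This account rests on a few compounds, and the source may have more. Where it says the series, first, only, none or still open, it means among the compounds named here.

Compound 1 `C=C1[C@H](O)[C@@H](O)[C@@H](O)C(C)(C)/C=C/[C@H](C)[C@H](OC(=O)c2ccccc2)[C@@]2(O)C[C@@](C)(O)[C@H](OC(C)=O)[C@@H]2[C@H]1OCC(C)C` is the starting point. In a functional assay on MCF7 cells (Homo sapiens) for antiproliferative activity, read by MTT assay, with a stated time of 48 h (a lower number here means a stronger inhibitor, a higher number a weaker inhibitor), compound 1 gives > 100000 nM as its reading, which is a limit of the assay and not a number. Its place on the scale is therefore known only as that limit.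

Compound 3 `C=C1[C@H](OC(=O)c2cccc(C)c2)[C@@H](O)[C@@H](O)C(C)(C)/C=C/[C@H](C)[C@H](OC(=O)c2ccccc2)[C@@]2(O)C[C@@](C)(O)[C@H](OC(C)=O)[C@@H]2[C@H]1OCC(C)C` differs from compound 1 in one place. The change is (3-methylphenyl)carbonyl in place of hydrogen on an oxygen on a saturated carbon in all, (3-methylphenyl)carbonyl in place of hydrogen on an oxygen on a saturated carbon whose other neighbours are saturated ring carbon.

Compound 2 `C=C1[C@H](O)[C@@H](OC(=O)c2cccc(C)c2)[C@@H](O)C(C)(C)/C=C/[C@H](C)[C@H](OC(=O)c2ccccc2)[C@@]2(O)C[C@@](C)(O)[C@H](OC(C)=O)[C@@H]2[C@H]1OCC(C)C` carries the same group on a different oxygen of the shared core and gives 63800 nM as a true number. For the measured compounds named here, the only measured step that bears on the change is an at least 1.5-fold lower number from compound 1 to compound 2 (0.19 log units; that floor lies within the scatter) and its floor lies within the scatter, so it proves no real gain. Resting on compound 2 and that step an at least 1.5-fold lower number from compound 1 to compound 2 (0.19 log units; that floor lies within the scatter) alone, a small drop in the number is expected in this assay and compound 3 could also stay at the limit. The expected step is an at least 1.8-fold lower number from compound 1 to compound 3 (0.25 log units; that floor lies within the scatter) by this estimate. Compound 3 is estimated at 55000 nM with an expected range from 20000 nM to 100000 nM in this assay.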

Compound 3, half-maximal inhibitory concentration: 21600 nM
For compound 3 the middle estimate is 2.5-fold (0.41 log units) above the measured one, within the range that was stated.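

Turning this hydroxy into ((3-methylphenyl)carbonyl)oxy gives an at least 4.6-fold lower number from compound 1 to compound 3 (0.66 log units; beyond the scatter) in this assay. The step with the same group on a different oxygen of the shared core, an at least 1.5-fold lower number from compound 1 to compound 2 (0.19 log units; that floor lies within the scatter), could not establish a real gain, so this is the first step shown to establish that adding this group to the core of compound 1 lowers the number. The true size of the new step stays unknown, and the two oxygens cannot be ranked by these steps, because compound 1 sits at a limit of the assay and not at a number: the limit of > 100000 nM in this assay, at which 1 of the 3 values shown sits.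

The compounds shown leave open whether the methyl on the aromatic ring matters at this oxygen, or whether a plain hexanoyl chain or an aromatic ring carrying an amine would give a lower or a higher number there. They also leave open what would happen with (3-methylphenyl)carbonyl groups on both of these oxygens at once.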